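Moving a Methyl Group Around the Ring

This account rests on a few compounds, and the source may have more. Where it says the series, first, only, none or still open, it means among the compounds named here.

Measured so far:
Compound 1 `CC1CCC(/C=N/c2ccc(F)cc2)=C2NC=C(C(=O)O)C(=O)N21` gives 10.6 umol/kg.
Compound 2 `CCOc1ccc(/N=C/C2=C3NC=C(C(=O)O)C(=O)N3C(C)CC2)cc1` gives 8.96 umol/kg.
Compound 3 `Cc1cccc(/N=C/C2=C3NC=C(C(=O)O)C(=O)N3C(C)CC2)c1` gives 0.8 umol/kg.

All three were tested in a functional assay on the whole organism with Rattus norvegicus as the target; a lower number here means that less compound is needed, a higher number that more compound is needed for the effect. Compound 3 stands lowest of the three numbers: its nearest neighbour is compound 2, and compound 1 is furthest from it, both gaps beyond the scatter.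

The new compound 4 `Cc1ccc(/N=C/C2=C3NC=C(C(=O)O)C(=O)N3C(C)CC2)cc1` keeps the same atoms as compound 3, joined differently: 4-methylphenyl in place of 3-methylphenyl on a double-bonded nitrogen. Within the data shown here, no measured step shifts a methyl group around the aromatic ring, so none bears on this change directly. Two steps give context. a 1.2-fold lower number from compound 1 to compound 2 (0.07 log units; within the scatter) shows that swapping one group for another at the same place can leave the number almost unchanged. a 13-fold lower number from compound 1 to compound 3 (1.12 log units; beyond the scatter) shows that changing the ring's substituent and its place together can move the number a great deal. Compounds 1 and 2 carry their groups where compound 4 carries its methyl, and both sit well above compound 3. Compound 4 is therefore expected to land between those levels, with a 5.0-fold higher number from compound 3 to compound 4 (0.70 log units; beyond the scatter) as the estimated step. For compound 4 the expected value is 4 umol/kg, within the range 1.2 umol/kg to 14 umol/kg.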

Compound 4, dose for 50% inhibition: 3.6 umol/kg
Compound 4: the middle estimate sits 1.1-fold (0.05 log units) above what was measured; low and high end bracket the measured number.
By their numbers in this assay, from the lowest: compound 3; then compound 4; then compounds 2 and 1 (each within the scatter of the next).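

In this assay shifting the methyl group alone, with every atom kept, brings a 4.5-fold higher number from compound 3 to compound 4 (0.65 log units; beyond the scatter) and so shows that its place on the aromatic ring matters in its own right. The earlier compounds shown here could not show this, since their steps changed the group itself. Methyl also gives a 2.5-fold lower number from compound 2 to compound 4 (0.40 log units; beyond the scatter) in place of ethoxy and a 2.9-fold lower number from compound 1 to compound 4 (0.47 log units; beyond the scatter) in place of fluoro, so the choice of group counts as well as its place. Nothing available explains why either change moves the number.

From the compounds shown here alone, only methyl appears here in both the 3-methylphenyl and 4-methylphenyl forms, so it remains open whether ethoxy or fluoro would follow the same order. Going by these compounds, it also remains open whether a chloro group, an amine or a longer chain on the ring would do so.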